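Working notes: methoxy on compound 3

A few compounds are considered here, and "the series" means these few. Any claim that something is new, unique, unknown or untested is made for them only; others in the source may bear on it.

compound 1 `O=C1/C(=C/c2ccc(F)cc2)CCC/C1=C\c1ccccc1[N+](=O)[O-]` gives 2700 nM
compound 2 `O=C1/C(=C/c2ccc(Cl)cc2)CCC/C1=C\c1ccccc1[N+](=O)[O-]` gives 3700 nM
compound 3 `O=C1/C(=C/c2ccccc2)CCC/C1=C\c1cccc([N+](=O)[O-])c1` gives 3700 nM

All three values come from a functional assay on HSC-2 cells (Homo sapiens) for cytotoxicity, with a stated time of 24 h (a lower number here means that less compound is tolerated, a higher number that more compound is tolerated), and lie within the scatter of one another. Compound 3 stands level with compound 2 at the digits shown, and its gap to compound 1 is within the scatter.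

The next structure is compound 4 `COc1ccc(/C=C2\CCC/C(=C\c3cccc([N+](=O)[O-])c3)C2=O)cc1` and the change is methoxy in place of hydrogen on an aromatic carbon with methoxy in place of hydrogen on an aromatic carbon, para to a large group.

For the measured compounds named here, only one measured step is available, namely a 1.4-fold higher number from compound 1 to compound 2 (0.14 log units; within the scatter) with chloro in place of fluoro on an aromatic carbon. That step exchanges one halogen for another, so it bears on the new change only loosely. Going by the values given here, no measured compound carries methoxy, and the data favour no direction. In this assay no step beyond the scatter is therefore expected. The estimated change is a 1.1-fold lower number from compound 3 to compound 4 (0.05 log units; within the scatter) and it should be read as an expectation only. For compound 4 the estimated value is 3300 nM with an expected range from 1400 nM to 7500 nM for now.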

Compound 4, half-maximal cytotoxic concentration: 4800 nM
The estimate for compound 4 lay 1.5-fold (0.16 log units) below the measured number; the range from low to high includes it.
By their numbers in this assay, from the lowest: compounds 1, 2, 3 and 4 (each within the scatter of the next).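

In this assay, phenyl to 4-methoxyphenyl gives a 1.3-fold higher number from compound 3 to compound 4 (0.11 log units; within the scatter), so methoxy in place of hydrogen on this aromatic carbon, para to a large group, produces no step beyond the scatter. For the compounds shown here, the only earlier step exchanged one halogen for another, whereas this one is the first reading of a group replacing hydrogen, and the series now holds a first oxygen-linked group at this position. Nothing at hand accounts for this reading, and it is taken here as an observation only.

Going by these compounds, whether an amine or a carboxylic acid at this same position would give a step beyond the scatter stays open. A single methoxy step also leaves open whether a longer chain, such as ethoxy or butoxy, would read the same way in this assay.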